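The source may hold more compounds than are shown below. What is called first, only, known or untested is meant among the compounds shown, and "the series" means these compounds.

In a functional assay on SGC-7901 cells (Homo sapiens) for antiproliferative activity, read by sulforhodamine B assay, with a stated time of 72 h (a higher number here means a weaker inhibitor, a lower number a stronger inhibitor), compound 1 `Cc1ccccc1NC(=S)N/N=C/c1ccc2ccccc2n1` is reported as > 100000 nM and this is a limit of the assay, not a number. For the measured compounds named here, compound 2 `FC(F)(F)c1ccc(NC(=S)N/N=C/c2ccc3ccccc3n2)cc1` gives 72200 nM and so holds the only actual number available so far. Compound 3 `S=C(N/N=C/c1ccc2ccccc2n1)Nc1ccccc1` arises from compound 2 through the change hydrogen in place of trifluoromethyl on an aromatic carbon and carries hydrogen in place of trifluoromethyl on an aromatic carbon. Going by the values given here, no measured step bears on this change. The estimated shift a 1.0-fold lower number from compound 2 to compound 3 (0.01 log units; within the scatter) stays within the usual scatter, so no real change is expected in this assay here. For compound 3 the estimated value is 70000 nM with an expected range from 20000 nM to 150000 nM as the likely span.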

Compound 3, half-maximal inhibitory concentration: 26500 nM
Beside the measured number, compound 3's estimate is 2.6-fold (0.42 log units) above it; low and high end bracket the measured number.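

In this assay, hydrogen in place of trifluoromethyl, para to a large group, gives a 2.7-fold lower number from compound 2 to compound 3 (0.44 log units; beyond the scatter), so at this position trifluoromethyl brings no gain over hydrogen. Hydrogen in place of methyl points the same way, with an at least 3.7-fold lower number from compound 1 to compound 3 (0.57 log units; beyond the scatter). That second step rests on compound 1, whose reported value is a limit and not a number: the limit of > 100000 nM in this assay, at which 1 of the 3 values shown sits.

The compounds shown leave open whether an amine, a methoxy group or a carboxylic acid on that aromatic carbon would give a lower number than hydrogen does.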